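From Benzyl to 4-(Trifluoromethyl)phenyl: A Step Without a Baseline

The source may hold more compounds than are shown below. What is called first, only, known or untested is meant among the compounds shown, and "the series" means these compounds.

Measured so far in an ADME assay on L6 cells (Rattus norvegicus) for cytotoxicity, read by resazurin assay, with a stated time of 70 h (on this read-out lower numbers stand for stronger inhibition and higher numbers for weaker inhibition), for each compound:
- compound 1 `COc1cc(NC(C)CCCNC(=O)NNC(=O)/C=C/c2ccc(C(F)(F)F)cc2)c2ncccc2c1` with 28300 nM as its result
- compound 2 `COc1cc(NC(C)CCCNC(=O)NNC(=O)NCc2ccccc2)c2ncccc2c1` with "not determined" (no result reported) as its result

Compound 2 has no place on this scale: in this assay compound 2 has only the entry "not determined" (no result reported) and no single number. Compound 3 `COc1cc(NC(C)CCCNC(=O)NNC(=O)Nc2ccc(C(F)(F)F)cc2)c2ncccc2c1` has not been measured yet. It keeps the core of compound 2 and changes one group 4-(trifluoromethyl)phenyl in place of benzyl on an amide-type nitrogen so that 4-(trifluoromethyl)phenyl takes the place of benzyl on an amide-type nitrogen.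

With no number for compound 2, the data show neither the size nor the direction of this step. The working expectation is therefore no step beyond the scatter. Among the measured compounds shown here, the only number available as a guide comes from compound 1, which also carries a 4-(trifluoromethyl)phenyl group and gives 28300 nM in this assay as its result. Compound 3 is expected to land in the same broad region. For compound 3 the estimated value is 20000 nM with an expected range from 6000 nM to 60000 nM in this read-out.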

Compound 3, half-maximal inhibitory concentration: 14900 nM
Compound 3: middle estimate off by 1.3-fold (0.13 log units), on the high side, and the stated range covers the measured number.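

In this assay, among the compounds shown here, (4-(trifluoromethyl)phenyl)amino in place of 2-(4-(trifluoromethyl)phenyl)ethenyl on a carbonyl carbon gives a 1.9-fold lower number from compound 1 to compound 3 (0.28 log units; within the scatter) and is the first step that can be read at all. The shared core and the 4-(trifluoromethyl)phenyl group stay the same in this pair, so only the link joining that group to the carbonyl carbon differs, and for these two compounds that difference does not move the result beyond the usual scatter. No measurement shown here bears on why the two compounds fall so close together.

The step from benzyl to 4-(trifluoromethyl)phenyl on the amide-type nitrogen still cannot be read, as compound 2 has no number on this scale. Also open, from the compounds shown here alone, is what a plain phenyl group, a carboxylic acid or an amine on a longer chain would give at this place, and whether compound 1 and compound 3 would stay this close if another group took the place of 4-(trifluoromethyl)phenyl in both.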